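Compound 3 trades 1,3-thiazol-2-yl for pyridin-2-yl

The source may hold more compounds than are shown below. What is called first, only, known or untested is meant among the compounds shown, and "the series" means these compounds.

Compound 1 `Cc1cc(C)nc(NS(=O)(=O)c2ccc(Nc3nncc4ccccc34)cc2)n1` gives 7.9 nM in a functional assay on COLO 205 cells (Homo sapiens) for antiproliferative activity, read by sulforhodamine B assay, with a stated time of 72 h (on this read-out lower numbers stand for stronger inhibition and higher numbers for weaker inhibition), while compound 2 `O=S(=O)(Nc1ncccn1)c1ccc(Nc2nncc3ccccc23)cc1` gives 43 nM and compound 3 `O=S(=O)(Nc1nccs1)c1ccc(Nc2nncc3ccccc23)cc1` gives 56 nM on the same scale. Two steps place compound 3: a clear one (a 7.1-fold higher number from compound 1 to compound 3 (0.85 log units; beyond the scatter)) beyond the scatter and a small one (a 1.3-fold higher number from compound 2 to compound 3 (0.11 log units; within the scatter)) within it. Compound 4 `O=S(=O)(Nc1ccccn1)c1ccc(Nc2nncc3ccccc23)cc1` keeps the shared core and carries pyridin-2-yl in place of 1,3-thiazol-2-yl on a sulfonamide nitrogen. For the measured compounds named here, the nearest precedent is that small step, since the larger ones (a 5.4-fold higher number from compound 1 to compound 2 (0.74 log units; beyond the scatter) and the one above) both remove 4,6-dimethylpyrimidin-2-yl. A change within the scatter is therefore expected (a 1.1-fold lower number from compound 3 to compound 4 (0.05 log units; within the scatter)) with no clear direction. Compound 4 is estimated at 50 nM with an expected range from 17 nM to 150 nM in this assay.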

Compound 4, half-maximal inhibitory concentration: 44 nM
Compound 4: middle estimate off by 1.1-fold (0.06 log units), on the high side, and the stated range covers the measured number.
By their numbers in this assay, from the lowest: compound 1; then compounds 2, 4 and 3 (each within the scatter of the next).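

Swapping the ring on the sulfonamide nitrogen from a five-membered to a six-membered one leaves the number within the scatter, with a 1.3-fold lower number from compound 3 to compound 4 (0.10 log units; within the scatter) as the step, and replacing pyrimidin-2-yl with pyridin-2-yl does the same, with a 1.0-fold higher number from compound 2 to compound 4 (0.01 log units; within the scatter) as the step. The ring without methyl groups can therefore take any of these three forms here, while 4,6-dimethylpyrimidin-2-yl stays apart from the new compound too, as a 5.6-fold higher number from compound 1 to compound 4 (0.75 log units; beyond the scatter) shows beyond the scatter. No measurement shown gives a reason for either result.

On these data alone, it remains open whether 4,6-dimethylpyridin-2-yl would match compound 1 and so carry the methyl effect over to a pyridine ring. Nor do these compounds show how a methoxy group or an amine would behave on the ring in place of the methyl groups.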